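The compounds below may be only part of what the source reports. "The series", "measured", "known", "first", "only" and "open" are said of these compounds alone.

Within the data shown here, in a functional assay on HepG2 cells (Homo sapiens), read by MTT assay, with a stated time of 48 h (a higher number here means a weaker inhibitor, a lower number a stronger inhibitor), compound 1 `CCn1c(C(=O)NCCCN(C)C)ccc1C(CC)(CC)c1ccc(OCC(=O)C(C)(C)C)c(C)c1` gives 960 nM, the middle of the three numbers measured so far. Compound 2 `CCn1c(C(=O)NCCCN(C)C)ccc1C(CC)(CC)c1ccc(OCC(O)C(C)(C)C)c(C)c1` gives 360 nM, and compound 3 `CCn1c(C(=O)N(CCC#N)CCC#N)ccc1C(CC)(CC)c1ccc(OCC(O)C(C)(C)C)c(C)c1` gives 42000 nM. Compound 4 `CC[C@@H](C)[C@H](NC(=O)c1ccc(C(CC)(CC)c2ccc(OCC(=O)C(C)(C)C)c(C)c2)n1CC)C(=O)O` has not yet been measured. It keeps the (tert-butyl)carbonyl of compound 1 and differs on the amide-type nitrogen: 1-carboxy-2-methylbutyl in place of 3-(dimethylamino)propyl on an amide-type nitrogen.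

The modest step of a 2.7-fold lower number from compound 1 to compound 2 (0.43 log units; beyond the scatter) concerns the (tert-butyl)carbonyl, which does not change here, so it says little about this comparison. The step that bears on it is the large one, a 120-fold higher number from compound 2 to compound 3 (2.07 log units; beyond the scatter), where the 3-(dimethylamino)propyl group also leaves, along with the rest of the group on the carbonyl carbon. Among the measured compounds shown here, this is a single step, taken with the 1-hydroxy-2,2-dimethylpropyl group in place, and no measured compound carries the 1-carboxy-2-methylbutyl group. For the measured compounds named here, with compound 3 at 42000 nM as the only measured compound lacking the 3-(dimethylamino)propyl group, a large step to a higher number, meaning a weaker inhibitor, is expected in this assay. The estimated change is a 31-fold higher number from compound 1 to compound 4 (1.49 log units; beyond the scatter). The expected value for compound 4 is 30000 nM, with an estimated range of 6000 nM to 100000 nM.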

Compound 4, half-maximal inhibitory concentration: 247 nM
Compound 4: the middle estimate sits 120-fold (2.08 log units) above what was measured, and the stated range ends above it.
By their numbers in this assay, from the lowest: compounds 4 and 2 (each within the scatter of the next); then compound 1; then compound 3.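

In this assay, putting 1-carboxy-2-methylbutyl in place of 3-(dimethylamino)propyl on the amide-type nitrogen gives a 3.9-fold lower number from compound 1 to compound 4 (0.59 log units; beyond the scatter), so at this position a low number does not depend on keeping the 3-(dimethylamino)propyl group. The large rise seen in the earlier step (a 120-fold higher number from compound 2 to compound 3 (2.07 log units; beyond the scatter)) therefore cannot be read as a general penalty for losing that group: it belongs to one replacement, the nitrile-bearing group on the carbonyl carbon, taken with the 1-hydroxy-2,2-dimethylpropyl group in place, whereas the new step was taken with the (tert-butyl)carbonyl in place. Nothing measured here explains why this position accepts the 1-carboxy-2-methylbutyl group.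

The compounds shown leave open whether the 1-carboxy-2-methylbutyl group would read the same with the 1-hydroxy-2,2-dimethylpropyl group in place, and what part its two defined stereocentres play. They also leave open how a shorter carboxymethyl chain, a methyl ester of the carboxylic acid or a piperidine-bearing chain on the same amide-type nitrogen would read in this assay.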